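Swapping an anilino link for a phenoxy link

The source may hold more compounds than are shown below. What is called first, only, known or untested is meant among the compounds shown, and "the series" means these compounds.

Measured compounds:
compound 1 `Cc1nc(OCc2c(-c3c(Cl)cccc3Cl)noc2C(C)C)ccc1N(C)C(=O)c1ccc(C(=O)O)cc1` with 365 nM
compound 2 `CC(Nc1ccc(C(=O)O)cc1)c1ccc(OCc2c(-c3c(Cl)cccc3Cl)noc2C2CC2)nc1C(F)(F)F` with 101 nM

Within the data shown here, in an assay on isolated protein for agonist activity at Bile acid receptor (Homo sapiens), read by FRET (a lower number here means that less compound is needed, a higher number that more compound is needed for the effect), compound 2 gives the lower of the two numbers measured so far; compound 1 gives the higher, and that gap lies beyond the usual scatter. Compound 3 `CC(Oc1ccc(C(=O)O)cc1)c1ccc(OCc2c(-c3c(Cl)cccc3Cl)noc2C2CC2)nc1C(F)(F)F` is not yet measured. It keeps the core of compound 2 and differs in one place: 4-carboxyphenoxy in place of (4-carboxyphenyl)amino on a saturated chain carbon bound to an aromatic carbon and a saturated chain carbon. One hydrogen-bond donor is lost in that exchange while the acid group stays.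

Among the measured compounds shown here, since no step between measured compounds addresses this kind of exchange, the expected size of the step can only be judged loosely. A small shift toward a higher number than compound 2 is expected, but it may well stay within the scatter. The estimated step from compound 2 to compound 3 is a 1.6-fold higher number from compound 2 to compound 3 (0.20 log units; within the scatter), and for compound 3 a value of 160 nM is estimated, with a range from 50 nM to 500 nM.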

Compound 3, half-maximal effective concentration: 352 nM
The estimate for compound 3 lay 2.2-fold (0.34 log units) below the measured number, within the range that was stated.
By their numbers in this assay, from the lowest: compound 2; then compounds 3 and 1 (each within the scatter of the next).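

In this assay, among these compounds, this is the first direct reading of the link at this place: with the rest of the structure unchanged, 4-carboxyphenoxy in place of (4-carboxyphenyl)amino gives a 3.5-fold higher number from compound 2 to compound 3 (0.54 log units; beyond the scatter) and so the link atom matters here. The two groups have the same number of heavy atoms and both keep the acid, but the entering group has one hydrogen-bond donor where the leaving group has 2. No measurement shown explains the step, so it cannot be credited to the lost donor or to any other single feature.

Still open, as far as these compounds go, is whether a sulfur link or an N-methylamino link would sit nearer compound 2 or compound 3. Whether the same exchange gives a step of similar size on another core is also unknown.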